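This account rests on a few compounds, and the source may have more. Where it says the series, first, only, none or still open, it means among the compounds named here.

Measured in a functional assay on a cell-free system (Platelet, plasma, Oryctolagus cuniculus) for inhibition, with a stated time of 5 min; on this read-out higher numbers stand for weaker inhibition and lower numbers for stronger inhibition:
- Compound 1 `CCOC(=O)/C=C/c1cc(Cl)ccc1OCc1nc(C)c(C)nc1C`: > 2000000 nM (a limit of the assay, not a number)
- Compound 2 `Cc1nc(C)c(COc2ccccc2/C=C/C(=O)O)nc1C`: 54000 nM

Among the measured compounds shown here, compound 2, at 54000 nM, holds the only actual number so far. The reading for compound 1 is a limit of the assay. The next compound to be tested is compound 3 `Cc1nc(C)c(COc2ccc(Cl)cc2/C=C/C(=O)O)nc1C`. It differs from compound 2 by one change: chloro in place of hydrogen on an aromatic carbon. Chloro takes the place of hydrogen on an aromatic carbon, meta to the 2-carboxyethenyl group and para to a large group. For the measured compounds named here, no two measured compounds differ in one place only, so no measured step sizes this change in this assay. The expectation is therefore modest, with no shift beyond the scatter in either direction, and the estimated step is a 1.2-fold lower number from compound 2 to compound 3 (0.08 log units; within the scatter). For compound 3 the expected value is 45000 nM, with an estimated range of 12000 nM to 170000 nM.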

Compound 3, half-maximal inhibitory concentration: 1050000 nM
For compound 3 the middle estimate is 23-fold (1.37 log units) below the measured one, and the stated range ends below it.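

In this assay, among the compounds shown here, the place meta to a 2-carboxyethenyl group and para to a large group is not neutral to substitution: chloro in place of hydrogen there gives a 19-fold higher number from compound 2 to compound 3 (1.29 log units; beyond the scatter), the first sized change, and it goes toward weaker inhibition. Hydrogen in place of ethyl, with chloro present on both compounds, gives an at least 1.9-fold lower number from compound 1 to compound 3 (0.27 log units; that floor lies within the scatter), which is only a floor, so the true size of that change stays unread. The reading for compound 1 is a limit of the assay, not a number, and that limit sets the floor: the limit of > 2000000 nM in this assay, at which 1 of the 3 values shown sits.

On these data alone, whether fluoro, methyl or an amine at this place would behave like chloro remains open. Also open, as far as these compounds go, is whether chloro elsewhere on the same ring carries the same penalty.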